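The source may hold more compounds than are shown below. What is called first, only, known or untested is meant among the compounds shown, and "the series" means these compounds.

Compound 3 `CC(C)(C)OC(=O)NCNC(=O)CN1CN(c2ccccc2)C2(CCN(C(=O)c3ccc(C4CCCCC4)cc3)CC2)C1=O` gives 1700 nM in an assay on HEK293 cells for displacement of a labelled ligand from NPC1-like intracellular cholesterol transporter 1 (Homo sapiens) (on this read-out lower numbers stand for stronger inhibition and higher numbers for weaker inhibition), the lowest of the three numbers obtained so far. Compound 1 `CC(C)(C)OC(=O)NCCCCNC(=O)CN1CN(c2ccccc2)C2(CCN(C(=O)c3ccc(C4CCCCC4)cc3)CC2)C1=O` gives 4600 nM and compound 2 `CCc1nn(CC)c(C2CCN(C(=O)CN3CN(c4ccccc4)C4(CCN(C(=O)c5ccc(C(C)(C)C)cc5)CC4)C3=O)CC2)c1CC` gives 4600 nM. Within the data shown here, the only single-site step measured is a 2.7-fold lower number from compound 1 to compound 3 (0.43 log units; beyond the scatter), a modest gain. Compound 4 `CC1(C)CC(OC(=O)CN2CN(c3ccccc3)C3(CCN(C(=O)c4ccc(C5CCCCC5)cc4)CC3)C2=O)CC(C)(C)N1` differs from compound 3 at a carbonyl carbon: (2,2,6,6-tetramethylpiperidin-4-yl)oxy in place of (((tert-butoxycarbonyl)amino)methyl)amino on a carbonyl carbon. Among the measured compounds shown here, no measured step alters this part of the molecule in the same way; the step from compound 1 to compound 3 only shortened the chain that is now replaced, and it shows that changes here shift the number modestly. A step of similar size, or none beyond the scatter, is therefore expected, and compound 4 is estimated at 2500 nM, within 600 nM to 10000 nM, which would mean a 1.5-fold higher number from compound 3 to compound 4 (0.17 log units; within the scatter).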

Compound 4, half-maximal inhibitory concentration: 600 nM
Compound 4: the middle estimate sits 4.2-fold (0.62 log units) above what was measured; measured number inside the range.
By their numbers in this assay, from the lowest: compound 4; then compound 3; then compounds 1 and 2 (each within the scatter of the next).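

On the carbonyl carbon, (2,2,6,6-tetramethylpiperidin-4-yl)oxy in place of (((tert-butoxycarbonyl)amino)methyl)amino gives a 2.8-fold lower number from compound 3 to compound 4 (0.45 log units; beyond the scatter) in this assay, so this position accepts a ring as well as an open chain. The change replaces several features at once, including the linking nitrogen and the tert-butoxycarbonyl group, and this single step cannot separate their contributions. No supporting data explain the shift.

Still open, as far as these compounds go, is whether (2,2,6,6-tetramethylpiperidin-4-yl)amino would give a similar number, with nitrogen replacing the linking oxygen. A plain piperidin-4-yloxy group, lacking the methyl groups, would test whether they matter.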